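The source may report more compounds than this note shows. Statements on the series, on what has been measured and on what is new or still open speak of the compounds shown alone.

The measured compounds:

Compound 1 `FC(F)(F)c1cccc(NC(=S)Nc2cccc(Br)c2)c1` gives 10000 nM in an ADME assay on MDBK cells (Bos taurus) for cytotoxicity, read by MTT assay, with a stated time of 96 h; on this read-out higher numbers stand for lower toxicity in this test and lower numbers for higher toxicity in this test.
Compound 2 `FC(F)(F)c1cccc(NC(=S)Nc2ccc(Cl)cc2)c1` gives 17000 nM in this assay.

Among the compounds with values here, only one step connects these two: a 1.7-fold higher number from compound 1 to compound 2 (0.23 log units; within the scatter), which lies within the scatter. On the numbers shown, compound 2 therefore carries the higher reading of the pair, but the gap to compound 1 is too small to count as a real difference, so the two compounds cannot be separated in this assay.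

Compound 3 `CC[C@H]1CC[C@H](c2ccc(NC(=S)Nc3cccc(C(F)(F)F)c3)cc2)CC1` is built from compound 2 by a change at one position: 4-ethylcyclohexyl in place of chloro on an aromatic carbon. Within the data shown here, the single measured step exchanged one halogen-bearing phenyl for another and did not move the number beyond the scatter; it says nothing about replacing a halogen with a 4-ethylcyclohexyl group. Among the measured compounds shown here, no measured step bears on this change. With nothing to point in either direction, the expected step of a 1.7-fold lower number from compound 2 to compound 3 (0.23 log units; within the scatter) is none beyond the scatter, with a wide margin of uncertainty. For compound 3 the estimate in this assay is 10000 nM, with a range from 2000 nM to 40000 nM.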

Compound 3, half-maximal cytotoxic concentration: 9000 nM
Compound 3: the middle estimate sits 1.1-fold (0.05 log units) above what was measured, within the range that was stated.
By their numbers in this assay, from the lowest: compounds 3, 1 and 2 (each within the scatter of the next).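

Replacing the chloro, a single chlorine atom, with 4-ethylcyclohexyl, which has 8 carbon atoms, one non-aromatic ring and 2 defined stereocentres, gives in this assay a 1.9-fold lower number from compound 2 to compound 3 (0.28 log units; within the scatter). The earlier step only exchanged one halogen-bearing phenyl for another, whereas this one shows that a halogen on this aromatic carbon can give way to a much bigger, carbon-only group with no difference in the reading that stands out from the scatter. Nothing measured here explains why the reading holds steady across so large a change in the group.

The compounds shown leave open whether the same holds for groups of a different kind at this position, such as an amine, a carboxylic acid or a longer straight alkyl chain, any of which could separate from compound 2 in a way that 4-ethylcyclohexyl does not. They also leave open whether the other arrangement of the two stereocentres in the 4-ethylcyclohexyl group would give a reading like that of compound 3.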